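The source may report more compounds than this note shows. Statements on the series, on what has been measured and on what is new or still open speak of the compounds shown alone.

Among the measured compounds shown here, the three compounds measured so far share one core. Compound 1 `Cc1nn(-c2ncnc3nc[nH]c23)c2c1C(c1ccc(OC(C)C)cc1)CC(=O)N2` carries a 4-isopropoxyphenyl group on a saturated ring carbon, and in a functional assay on HEK293 cells for agonist activity at G-protein coupled receptor 39 (Homo sapiens), read by scintillation proximity assay and inositol phosphate accumulation, with a stated time of 75 min (on this read-out lower numbers stand for an effect already at smaller amounts and higher numbers for an effect only at larger amounts of compound), compound 1 gives 2700 nM, the highest of the three numbers. Compound 2 `Cc1nn(-c2ncnc3nc[nH]c23)c2c1C(c1ccc(F)cc1Cl)CC(=O)N2` gives 280 nM in this assay, and compound 3 `Cc1nn(-c2ncnc3nc[nH]c23)c2c1C(C(=O)NCc1ccc(F)cc1)CC(=O)N2` gives 1220 nM. For the measured compounds named here, the only measured step at this saturated ring carbon is a 9.6-fold lower number from compound 1 to compound 2 (0.98 log units; beyond the scatter). Compound 4 `Cc1nn(-c2ncnc3nc[nH]c23)c2c1C(C(=O)NCc1ccccc1)CC(=O)N2` has not yet been measured. It differs from compound 1 in this way: benzylcarbamoyl in place of 4-isopropoxyphenyl on a saturated ring carbon. Going by the values given here, no measured step covers exactly this change. The step from compound 1 to compound 2 shows that replacing the 4-isopropoxyphenyl group at this place can lower the number, and compound 3, which carries a closely related group at the same place, stands below compound 1 in this assay but well above compound 2. A downward step of small size is therefore expected. The step expected for compound 4 is a 1.8-fold lower number from compound 1 to compound 4 (0.26 log units; within the scatter). The estimate for compound 4 is 1500 nM, expected to fall between 600 nM and 4000 nM.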

Compound 4, half-maximal effective concentration: 2930 nM
Estimate against measurement, compound 4: 2.0-fold (0.29 log units) below; low and high end bracket the measured number.
By their numbers in this assay, from the lowest: compound 2; then compound 3; then compounds 1 and 4 (each within the scatter of the next).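

In this assay, benzylcarbamoyl in place of 4-isopropoxyphenyl on the saturated ring carbon gives a 1.1-fold higher number from compound 1 to compound 4 (0.04 log units; within the scatter) and so the two groups cannot be told apart at this place. The fluoro on the aromatic carbon of the benzylcarbamoyl group does count, since hydrogen in its place gives a 2.4-fold higher number from compound 3 to compound 4 (0.38 log units; beyond the scatter) in a modest step beyond the scatter. The 2-chloro-4-fluorophenyl group keeps a large lead over benzylcarbamoyl at this place, with a 10-fold higher number from compound 2 to compound 4 (1.02 log units; beyond the scatter) on exchanging the two. Nothing measured here gives a reason for these differences. The compounds shown leave open whether a chloro on the aromatic ring of the benzylcarbamoyl group, or a phenethylcarbamoyl group at the same carbon, would bring the number closer to that of compound 2.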